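Swapping the Pentyl Chain for Cyclohexyl on the Amide

The compounds below may be only part of what the source reports. "The series", "measured", "known", "first", "only" and "open" are said of these compounds alone.

Of the compounds shown here, three built on one shared core have been tested in a functional assay on QGY7701 cells (Homo sapiens) for cytotoxicity, read by MTT assay, with a stated time of 24 h; a higher number here means a weaker inhibitor, a lower number a stronger inhibitor. Compound 1 `C=CC1=C(C(=O)NCCCCC)C(c2ccc(OC)cc2)OC1` returns only > 100000 nM, which is a limit of the assay rather than a measured number. Compound 2 `C=CC1=C(C(=O)Nc2ccccc2)C(c2ccc(Cl)c(Cl)c2)OC1` likewise returns > 100000 nM, again a limit and not a number. Within the data shown here, compound 3 `C=CC1=C(C(=O)Nc2ccccc2OC)C(c2ccc(F)cc2)OC1` is the one compound with an actual value, giving 52800 nM in this assay, a weak result. Compound 1 therefore stands at the limit of > 100000 nM in this assay, at which 2 of the 3 values shown sit, so all that is known of it is that it sits at the weak end of what the assay can report. Among the measured compounds shown here, no two of the measured compounds differ in a single place, so no measured step is available to show how one change moves the read-out.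

Compound 4 `C=CC1=C(C(=O)NC2CCCCC2)C(c2ccc(OC)cc2)OC1` is the next compound to be measured. Compared with compound 1 it differs in one place: cyclohexyl in place of pentyl on an amide-type nitrogen. With compound 1 itself already at the limit, there is no measured basis for expecting this change to bring a step beyond the usual scatter in either direction in this assay. The step is expected to be a step that the limit leaves unreadable from compound 1 to compound 4, essentially no change. Compound 4 is therefore estimated to give about 120000 nM, with a likely range from 40000 nM to 300000 nM, and most probably it will again be reported only as a limit.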

Compound 4, half-maximal inhibitory concentration: > 100000 nM
Compound 4 ended at the assay's limit (the forecaster's own chance of this, stated with the estimate: 75%); the middle value is on the limit's open side.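

Among these compounds, compound 1 and compound 4 both stand at a limit rather than at a number, so swapping pentyl for cyclohexyl gives no step that can be read in this assay. Most of the series now sits in the same place: the limit of > 100000 nM in this assay, at which 3 of the 4 values shown sit.

Going by these compounds, the real strength of compound 1 and compound 4 stays open, as does whether another group on that amide-type nitrogen would give a measurable value.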